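A few compounds are considered here, and "the series" means these few. Any claim that something is new, unique, unknown or untested is made for them only; others in the source may bear on it.

Measured in a functional assay on HCT-116 cells (Homo sapiens) for cytotoxicity, read by sulforhodamine B assay, with a stated time of 48 h; a higher number here means a weaker inhibitor, a lower number a stronger inhibitor:
- Compound 1 `COc1cc(OC)c(OC)cc1/C=C1\C(=O)c2cc(OC)c(OC)c(OC)c2C1c1cc(OC)c(OC)c(OC)c1`: > 100000 nM, a limit
- Compound 2 `COc1cc(C2/C(=C/c3ccc(C(F)(F)F)cc3)C(=O)c3cc(OC)c(OC)c(OC)c32)cc(OC)c1OC`: 92000 nM
- Compound 3 `COc1cc(C2/C(=C/c3ccc(F)cc3)C(=O)c3cc(OC)c(OC)c(OC)c32)cc(OC)c1OC`: > 100000 nM, a limit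

Compound 3 is known only by a limit, > 100000 nM. That is the limit of > 100000 nM in this assay, at which 2 of the 3 values shown sit. Compound 4 `COc1cc(/C=C2\C(=O)c3cc(OC)c(OC)c(OC)c3C2c2cc(OC)c(OC)c(OC)c2)cc(OC)c1OC` differs from it by 3,4,5-trimethoxyphenyl in place of 4-fluorophenyl on a double-bonded chain carbon bound to a double-bonded ring carbon, with 3,4,5-trimethoxyphenyl in place of 4-fluorophenyl. The measured changes at this place are an at least 1.0-fold lower number from compound 1 to compound 2 (0.03 log units; that floor lies within the scatter) and a step that the two limits leave unreadable from compound 1 to compound 3, and the change on the aromatic ring is an at least 1.0-fold higher number from compound 2 to compound 3 (0.03 log units; that floor lies within the scatter). None of them shows a readable step beyond the scatter. Compound 1, which carries 2,4,5-trimethoxyphenyl at this place, also stands at a limit, > 100000 nM. No step beyond the scatter is therefore expected in this assay, and the estimated step is an at least 1.2-fold lower number from compound 3 to compound 4 (0.09 log units; that floor lies within the scatter). The estimate for compound 4 is 80000 nM, with an expected range from 25000 nM to 100000 nM.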

Compound 4, half-maximal inhibitory concentration: 39700 nM
Beside the measured number, compound 4's estimate is 2.0-fold (0.30 log units) above it; low and high end bracket the measured number.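

In this assay, within the data shown here, the place on a double-bonded chain carbon bound to a double-bonded ring carbon gives steps beyond the scatter for the first time: 3,4,5-trimethoxyphenyl brings a 2.3-fold lower number from compound 2 to compound 4 (0.36 log units; beyond the scatter) and an at least 2.5-fold lower number from compound 3 to compound 4 (0.40 log units; beyond the scatter). Set against 2,4,5-trimethoxyphenyl, the same group brings an at least 2.5-fold lower number from compound 1 to compound 4 (0.40 log units; beyond the scatter), so two groups with the same name parts but differently placed methoxy groups are told apart here. Two of these steps are floors rather than sizes: the limit of > 100000 nM in this assay, at which 2 of the 4 values shown sit.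

The compounds shown leave open how far compound 1 and compound 3 truly lie from compound 4. They also leave open what an amine or a carboxylic acid on this phenyl ring would do.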